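The compounds below may be only part of what the source reports. "The series", "measured", "known", "first", "only" and "open" are said of these compounds alone.

Compounds measured so far:
compound 1, `Cc1cc(Nc2cc(N3CCN(C)CC3)nc(Nc3ccc(S(N)(=O)=O)cc3)n2)n[nH]1`, 1430 nM;
compound 2, `COc1ccc(Nc2nc(Nc3cc(C)[nH]n3)cc(N3CCN(C)CC3)n2)cc1`, 271 nM.

Compound 2 holds the lower of the two numbers in a functional assay on K562 cells (Homo sapiens) for antiproliferative activity, read by CCK-8 assay, with a stated time of 72 h; on this read-out higher numbers stand for weaker inhibition and lower numbers for stronger inhibition; compound 1 sits at 1430 nM, and the step of a 5.3-fold lower number from compound 1 to compound 2 (0.72 log units; beyond the scatter) lies beyond the scatter.

Compound 3, `Cc1cc(Nc2cc(N3CCN(C)CC3)nc(Nc3ccc([N+](=O)[O-])cc3)n2)n[nH]1`, has not yet been measured in this assay. It differs from compound 2 by nitro in place of methoxy on an aromatic carbon, the nitro sitting on an aromatic carbon of a six-membered aromatic ring of carbon only, para to a large group.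

Going by the values given here, only one measured step bears on this change, and only loosely: a 5.3-fold lower number from compound 1 to compound 2 (0.72 log units; beyond the scatter), where a methoxy replaced a sulfamoyl at the same place. Among the compounds with values here, the present step puts a nitro in the place of that methoxy; no measured pair shows a nitro here, so the direction can only be guessed from the fact that moving away from methoxy in the one known case gave a higher number. Compound 3 is therefore expected to come out somewhat weaker than compound 2, by a step of about a 2.2-fold higher number from compound 2 to compound 3 (0.35 log units; beyond the scatter), with wide uncertainty. The estimate for compound 3 is 600 nM, within 200 nM to 2000 nM.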

Compound 3, half-maximal inhibitory concentration: 137 nM
Beside the measured number, compound 3's estimate is 4.4-fold (0.64 log units) above it; measured number outside the range, below it.
By their numbers in this assay, from the lowest: compounds 3 and 2 (each within the scatter of the next); then compound 1.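

In this assay, the change from methoxy to nitro on an aromatic carbon of a six-membered aromatic ring of carbon only, para to a large group, reads as a 2.0-fold lower number from compound 2 to compound 3 (0.30 log units; within the scatter) and so leaves the number unchanged within the usual variation; the higher number seen earlier with sulfamoyl therefore does not follow from every replacement of methoxy at this place. Nitro in place of sulfamoyl gives a 10-fold lower number from compound 1 to compound 3 (1.02 log units; beyond the scatter) and this large step, together with the earlier 5.3-fold lower number from compound 1 to compound 2 (0.72 log units; beyond the scatter), sets sulfamoyl apart from both other groups, so that among these three compounds the position tolerates two quite different groups while only sulfamoyl carries a clear penalty. Nothing available here accounts for why sulfamoyl differs from methoxy and nitro at this place.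

The compounds shown leave open whether an amine, a carboxylic acid or a longer chain such as ethoxy at this place would group with methoxy and nitro or with sulfamoyl. They also leave open whether a plain hydrogen here would keep the number in the same range, and whether the same tolerance would hold in any read-out other than this assay.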